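The source may hold more compounds than are shown below. What is called first, only, known or untested is meant among the compounds shown, and "the series" means these compounds.

Compound 1 `OCc1cc2cc(/C(=N\O)Nc3cccc(Cl)c3)ccc2o1` gives 8000 nM in an assay on isolated protein for inhibition of Indoleamine 2,3-dioxygenase 1 (Homo sapiens), read by spectrophotometry (on this read-out higher numbers stand for weaker inhibition and lower numbers for stronger inhibition), the higher of the two numbers recorded so far. Among the compounds with values here, compound 2 `OCc1cc2cc(/C(=N\O)Nc3cccc(Br)c3)ccc2o1` gives 710 nM in this assay, and the only measured step, an 11-fold lower number from compound 1 to compound 2 (1.05 log units; beyond the scatter), concerns the halogen on the aromatic ring. Compound 3 `O/N=C(/Nc1cccc(Cl)c1)c1ccc2oc(COCC3CC3)cc2c1` differs from compound 1 at a different site: cyclopropylmethyl in place of hydrogen on an oxygen on a saturated carbon. Within the data shown here, no measured pair bears on this change, as the one step recorded touches only the bromo-for-chloro exchange and leaves the hydroxymethyl untouched. There is therefore nothing in the data to suggest that the number in this assay should move beyond the scatter, and the expectation for compound 3 is a step of no change at the digits printed from compound 1 to compound 3 (within the scatter), with the uncertainty widened for want of a precedent. Compound 3 is accordingly estimated at 8000 nM, within a range of 2000 nM to 30000 nM.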

Compound 3, half-maximal inhibitory concentration: 1500 nM
Compound 3: middle estimate off by 5.3-fold (0.73 log units), on the high side; measured number below the stated range.
By their numbers in this assay, from the lowest: compound 2; then compound 3; then compound 1.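

In this assay, cyclopropylmethyl on the oxygen of the hydroxymethyl group gives a 5.3-fold lower number from compound 1 to compound 3 (0.73 log units; beyond the scatter) and so shows that this site, untouched in the earlier pair, can also move the number beyond the scatter. With the chloro group in place, the free hydroxy hydrogen is therefore not needed for inhibition, and the cyclopropylmethoxy compound is the stronger of the two. Nothing in the data accounts for this gain. Going by these compounds, it remains open whether a plain methyl or a longer straight chain on that oxygen, or an amine in place of the hydroxy group, would move the number as far. On these data alone, it is equally open whether this step and the bromo-for-chloro step would add up if both changes stood in a single compound.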